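Trimming the Isopropyl Group of Compound 2

The source may hold more compounds than are shown below. What is called first, only, known or untested is meant among the compounds shown, and "the series" means these compounds.

Compound 1 `CC(C)[C@H](NC(=S)NCc1ccccc1)c1nc2ccccc2[nH]1`: 48500 nM
Compound 2 `CC(C)[C@H](NC(=S)Nc1ccccc1)c1nc2ccccc2[nH]1`: 12300 nM
Compound 3 `CC(C)[C@@H](NC(=S)Nc1ccccc1)c1nc2ccccc2[nH]1`: 34800 nM

In a functional assay on DU-145 cells (Homo sapiens) for cytotoxicity, read by MTT assay (a lower number here means a stronger inhibitor, a higher number a weaker inhibitor), compound 2 is the strongest inhibitor of the three, with 12300 nM. Compound 4 `C[C@H](NC(=S)Nc1ccccc1)c1nc2ccccc2[nH]1` differs from it in one place: methyl in place of isopropyl on a saturated chain carbon bound to an amide-type nitrogen and an aromatic carbon. Among the compounds with values here, no measured step changes this group. The closest guides to size are a 3.9-fold lower number from compound 1 to compound 2 (0.60 log units; beyond the scatter) and a 2.8-fold higher number from compound 2 to compound 3 (0.45 log units; beyond the scatter), both modest. The second rests on (the fact that compounds 2 and 3 differ only in the configuration as drawn), so the arrangement at this same carbon does shift the number. A modest step in this assay is therefore expected, slightly more likely towards a higher number, although no measurement fixes the direction. The expected change is a 1.8-fold higher number from compound 2 to compound 4 (0.25 log units; within the scatter). For compound 4 the estimated value is 22000 nM, with an expected range of 7000 nM to 70000 nM.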

Compound 4, half-maximal inhibitory concentration: "not active" (no number reported)
Compound 4 has no reported number here; no gap can be computed for the estimate.
By their numbers in this assay, from the lowest: compound 2; then compounds 3 and 1 (each within the scatter of the next).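

Compound 4 is reported as "not active" in this assay with no number, so no step can be read from compound 2 to compound 4. The compounds shown leave open how far methyl in place of isopropyl actually moves the number.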